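The compounds below may be only part of what the source reports. "The series", "measured", "known", "first", "only" and "open" are said of these compounds alone.

Working notes on the thiosemicarbazone series. Compound 1 `CC1=CC[C@H](C(C)(C)NC(=S)N/N=C/c2ccccc2)CC1` gives 20500 nM in an ADME assay on Vero cells (Chlorocebus sabaeus) for inhibition, read by sulforhodamine B assay, with a stated time of 48 h; a higher number here means a weaker inhibitor of growth, a lower number a stronger inhibitor of growth. Compound 2 `CC1=CC[C@H](C(C)(C)NC(=S)N/N=C/c2ccc(O)cc2)CC1` reaches only the limit of > 100000 nM in this assay; the value is a limit, not a number. Compound 3 `CC1=CC[C@H](C(C)(C)NC(=S)N/N=C/c2ccc(Cl)cc2)CC1` gives 70000 nM in this assay and stands highest of the two numbers given; its nearest neighbour is compound 1, with a 3.4-fold higher number from compound 1 to compound 3 (0.53 log units; beyond the scatter). The other substitution, an at least 4.8-fold higher number from compound 1 to compound 2 (0.68 log units; beyond the scatter), also raised the number, and an at least 1.4-fold lower number from compound 2 to compound 3 (0.15 log units; that floor lies within the scatter) is a floor within the scatter; one of the three values sits at the limit of > 100000 nM in this assay, at which 1 of the 3 values shown sits.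

Compound 4 `CC1=CC[C@H](C(C)(C)NC(=S)N/N=C/c2ccc[nH]2)CC1` is not yet measured. The change is 1H-pyrrol-2-yl in place of 4-chlorophenyl on a carbon with a double bond to nitrogen. Among the compounds with values here, no measured step exchanges the whole aromatic ring; the measured steps only swap a substituent on it, and both moved the number up from compound 1 by modest amounts. Compound 4 is therefore expected near the unsubstituted end of the series, an expected step of a 2.3-fold lower number from compound 3 to compound 4 (0.37 log units; beyond the scatter), with an estimate of 30000 nM and a range from 8000 nM to 120000 nM in this assay.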

Compound 4, concentration for 50% growth inhibition: 20500 nM
Estimate against measurement, compound 4: 1.5-fold (0.17 log units) above, within the range that was stated.
By their numbers in this assay, from the lowest: compounds 1 and 4 (each within the scatter of the next); then compound 3. At a limit, above all of these: compound 2.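

Within the data shown here, compound 4 is the first exchange of the whole aromatic ring on this carbon with a double bond to nitrogen, and the step from phenyl to 1H-pyrrol-2-yl in this assay reads no change at the digits printed from compound 1 to compound 4 (within the scatter) for this change. The ring exchange therefore leaves compound 4 level with compound 1, and both substituted phenyl compounds stand apart from it: a 3.4-fold lower number from compound 3 to compound 4 (0.53 log units; beyond the scatter) and an at least 4.8-fold lower number from compound 2 to compound 4 (0.68 log units; beyond the scatter) in the same assay. The second of these steps has a floor and not a full size, since the value of compound 2 is a limit and not a number: the limit of > 100000 nM in this assay, at which 1 of the 4 values shown sits.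

Open, going by these compounds, is whether a chloro or hydroxy on the 1H-pyrrol-2-yl ring raises the number as it does on phenyl. Also open, on these data alone, is what an amine or a carboxylic acid on the aromatic ring would do in this assay at this place.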